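This account rests on a few compounds, and the source may have more. Where it says the series, first, only, none or still open, it means among the compounds named here.

Of the compounds shown here, two have been measured so far in an assay on IMR-32 cells for inhibition of Voltage-dependent N-type calcium channel subunit alpha-1B (Homo sapiens), with a stated time of 5 min; a lower number here means a stronger inhibitor, a higher number a weaker inhibitor. Compound 2 `COC(OC)C1=C(C(=O)OC/C=C/c2ccccc2)C(c2cc(Cl)cc(Cl)c2)C(C(=O)O)=CN1` gives 1000 nM, and compound 1 `COC(OC)C1=C(C(=O)OC/C=C/c2ccccc2)C(c2ccc(Cl)cc2)C(C(=O)O)=CN1` gives 1100 nM; the step of a 1.1-fold lower number from compound 1 to compound 2 (0.04 log units; within the scatter) shows that moving from 4-chlorophenyl to 3,5-dichlorophenyl changed little. Compound 2 thus holds the lower of the two numbers, yet sits within the scatter of compound 1, so neither can be called stronger.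

Compound 3 `COC(OC)C1=C(C(=O)OC/C=C/c2ccccc2)C(c2ccc(Cl)c(Cl)c2)C(C(=O)O)=CN1` differs from compound 2 only in the dichlorophenyl pattern: 3,4-dichlorophenyl in place of 3,5-dichlorophenyl on a saturated ring carbon. Among the compounds with values here, the one measured step that bears on a rearrangement of chlorine atoms on this aromatic ring, a 1.1-fold lower number from compound 1 to compound 2 (0.04 log units; within the scatter), lay within the scatter. The expectation for compound 3 is therefore no step beyond the scatter in this assay, no change at the digits printed from compound 2 to compound 3 (within the scatter). Compound 3 is estimated at 1000 nM, with a likely range from 500 nM to 2000 nM.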

Compound 3, half-maximal inhibitory concentration: 520 nM
Estimate against measurement, compound 3: 1.9-fold (0.28 log units) above; measured number inside the range.
By their numbers in this assay, from the lowest: compounds 3, 2 and 1 (each within the scatter of the next, the first and the last beyond it).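

In this assay, within the data shown here, the change from 4-chlorophenyl to 3,4-dichlorophenyl gives a 2.1-fold lower number from compound 1 to compound 3 (0.33 log units; beyond the scatter), the first step in this short series to pass the scatter, though only modestly. Rearranging the two chlorine atoms from 3,5-dichlorophenyl to 3,4-dichlorophenyl gives a 1.9-fold lower number from compound 2 to compound 3 (0.28 log units; within the scatter), which stays within the scatter, so these two patterns cannot be told apart and neither can be called the stronger. Nothing available here explains either step.

Still open, as far as these compounds go, is how this ring carbon would respond to a plain phenyl, or to a fluorine, methoxy group or nitrile in place of chlorine on the aromatic ring. The compounds shown also leave open whether the carboxylic acid on the shared core matters, as a methyl ester or a primary amide in its place would show.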